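Swapping the group on the sulfonyl sulfur of compound 3

A few compounds are considered here, and "the series" means these few. Any claim that something is new, unique, unknown or untested is made for them only; others in the source may bear on it.

compound 1 `O=C(NCc1ccc(S(=O)(=O)c2cccc(C(F)(F)F)c2)cc1)N1Cc2ccncc2C1` gives 2.7 nM
compound 2 `CCC(=O)N1CCC(S(=O)(=O)c2ccc(CNC(=O)N3Cc4ccncc4C3)cc2)CC1` gives 54 nM
compound 3 `CN1CCC(S(=O)(=O)c2ccc(CNC(=O)N3Cc4ccncc4C3)cc2)CC1` gives 99 nM

All three values come from a functional assay on A2780 cells (Homo sapiens) for cytotoxicity, read by sulforhodamine B assay, with a stated time of 72 h; a higher number here means a weaker inhibitor, a lower number a stronger inhibitor. Compound 3 sits close to one neighbour and far from the other. The numbers show a 1.8-fold higher number from compound 2 to compound 3 (0.26 log units; within the scatter), and also a 37-fold higher number from compound 1 to compound 3 (1.56 log units; beyond the scatter).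

The next compound is compound 4 `O=C(NCc1ccc(S(=O)(=O)N2CCC(N3CCCC3)CC2)cc1)N1Cc2ccncc2C1`, which keeps the shared core and changes only the group on the sulfonyl sulfur: 4-(pyrrolidin-1-yl)piperidin-1-yl in place of 1-methylpiperidin-4-yl on a sulfonyl sulfur.

Two measured steps replaced a group at this same place, and both were large: a 20-fold higher number from compound 1 to compound 2 (1.30 log units; beyond the scatter) and a 37-fold higher number from compound 1 to compound 3 (1.56 log units; beyond the scatter). Compound 4 also has a piperidine ring on the sulfonyl sulfur and no 3-(trifluoromethyl)phenyl, so it should resemble compound 2 and compound 3 more than compound 1. Changing the group on the ring nitrogen mattered little, as a 1.8-fold higher number from compound 2 to compound 3 (0.26 log units; within the scatter) shows. Within the data shown here, no measured compound carries 4-(pyrrolidin-1-yl)piperidin-1-yl, so this comparison is only a rough guide.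

In this assay, no step beyond the scatter is expected, and the estimate is a 1.4-fold lower number from compound 3 to compound 4 (0.15 log units; within the scatter). For compound 4 the expected value is 70 nM, with an estimated range from 20 nM to 250 nM.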

Compound 4, half-maximal inhibitory concentration: 5.6 nM
Beside the measured number, compound 4's estimate is 13-fold (1.10 log units) above it; the measured number lies below the stated range.
By their numbers in this assay, from the lowest: compound 1; then compound 4; then compounds 2 and 3 (each within the scatter of the next).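

Until now, every group without the 3-(trifluoromethyl)phenyl had cost a great deal in this assay, yet 4-(pyrrolidin-1-yl)piperidin-1-yl recovers most of that loss, with an 18-fold lower number from compound 3 to compound 4 (1.25 log units; beyond the scatter) and a 9.6-fold lower number from compound 2 to compound 4 (0.98 log units; beyond the scatter). A small gap to the aromatic group remains, with a 2.1-fold higher number from compound 1 to compound 4 (0.32 log units; beyond the scatter), so among the compounds shown an aromatic ring on the sulfonyl sulfur is not needed for a low number, and the choice of non-aromatic group at this place can matter far more than the change on the ring nitrogen suggested. Nothing available explains why this group gives so much lower a number than the other two piperidine groups.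

Compound 4 changes two things at once, the atom of the piperidine ring that meets the sulfonyl sulfur and the added pyrrolidine ring, so the compounds shown cannot say which of the two carries the gain. As far as these compounds go, a plain piperidin-1-yl or a 4-(dimethylamino)piperidin-1-yl on the sulfonyl sulfur would help separate these two changes, and whether the gain holds in other cell lines also remains open.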